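The source may hold more compounds than are shown below. What is called first, only, known or untested is meant among the compounds shown, and "the series" means these compounds.

Compound 1 `O=C(CN1CCN(C(=O)c2cccc(Br)c2)CC1)N1CCN(CCCc2c[nH]c3ccccc23)CC1` is the starting point; in an ADME assay on SH-SY5Y cells (Homo sapiens) for cytotoxicity, read by MTT assay, with a stated time of 72 h (on this read-out lower numbers stand for stronger inhibition and higher numbers for weaker inhibition), compound 1 gives 80500 nM. Compound 2 `O=C(CN1CCN(C(=O)c2cccc(F)c2)CC1)N1CCN(CCCc2c[nH]c3ccccc23)CC1` differs from it by fluoro in place of bromo on an aromatic carbon, and in this assay compound 2 gives 165000 nM, so that a 2.0-fold higher number from compound 1 to compound 2 (0.31 log units; beyond the scatter). Compound 3 `O=C(CN1CCN(C(=O)c2cccc(Br)c2)CC1)N1CCN(CCCc2c[nH]c3ccc(F)cc23)CC1` differs from compound 1 by fluoro in place of hydrogen on an aromatic carbon; in this assay compound 3 gives 71600 nM, and a 1.1-fold lower number from compound 1 to compound 3 (0.05 log units; within the scatter). Compound 4 `O=C(CN1CCN(C(=O)c2cccc(F)c2)CC1)N1CCN(CCCc2c[nH]c3ccc(F)cc23)CC1` stands to compound 3 as compound 2 stands to compound 1: the change is fluoro in place of bromo on an aromatic carbon, the same change, at the same kind of place, made on the core of compound 3 instead of the core of compound 1. For compound 4 the expected step is a 2.0-fold higher number from compound 3 to compound 4 (0.31 log units; beyond the scatter), which rests on a 2.0-fold higher number from compound 1 to compound 2 (0.31 log units; beyond the scatter) and on compound 3 at 71600 nM. Compound 4 is therefore estimated at 145000 nM, with a likely range from 80000 nM to 270000 nM.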

Compound 4, half-maximal inhibitory concentration: 169000 nM
For compound 4 the middle estimate is 1.2-fold (0.07 log units) below the measured one; measured number inside the range.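

In this assay, replacing bromo with fluoro on the core of compound 3 gives a 2.4-fold higher number from compound 3 to compound 4 (0.37 log units; beyond the scatter), and this step matches the one seen on the core of compound 1: the same change on two cores in this assay, a 2.0-fold higher number (0.31 log units; beyond the scatter) from compound 1 to compound 2 and a 2.4-fold higher number (0.37 log units; beyond the scatter) from compound 3 to compound 4, 1.2-fold (0.06 log units) apart, within the scatter of two such steps. The other change, fluoro in place of hydrogen on an aromatic carbon, gives a 1.0-fold higher number from compound 2 to compound 4 (0.01 log units; within the scatter), and it also carries across the two cores without a measurable difference: the same change on two cores in this assay, a 1.1-fold lower number (0.05 log units; within the scatter) from compound 1 to compound 3 and a 1.0-fold higher number (0.01 log units; within the scatter) from compound 2 to compound 4, 1.2-fold (0.06 log units) apart, within the scatter of two such steps. These four compounds show that both changes carry over between these two cores in this single assay, but they do not show that either would carry over to other cores or other assays.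

On these data alone, it remains open whether a chloro or methoxy group in place of the bromo would follow the same course. A longer chain in the shared core is also untested among these compounds.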